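A few compounds are considered here, and "the series" means these few. Any claim that something is new, unique, unknown or untested is made for them only; others in the source may bear on it.

Working notes on the series.

Compound 1 `CCC(C)N(Cc1cccs1)C(=O)COc1ccc(C)cc1` sits second highest of the three numbers measured in an assay on HEK293 cells for agonist activity at transient receptor potential cation channel subfamily M member 8 (Homo sapiens), read by fluorescence and calcium flux, with a stated time of 15 min (a lower number here means that less compound is needed, a higher number that more compound is needed for the effect), where compound 1 gives 2000 nM. Compound 2 `CCN(Cc1cccs1)C(=O)COc1ccc2c(c1)CCCC2` gives 689 nM in this assay, the lower number of the two, while compound 3 `CCN(Cc1cccs1)C(=O)C(C)(C)Oc1ccc(C)cc1` gives 11000 nM, the highest of the set; the gaps from compound 1 to each of them are beyond the usual scatter. Within the data shown here, no step between two measured compounds that differ in a single place is available, so nothing here isolates the effect of the group on the amide-type nitrogen.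

Compound 4 `Cc1ccc(OCC(=O)N(Cc2cccs2)C2CC2)cc1` is the next compound for this assay. Against compound 1 the change is cyclopropyl in place of sec-butyl on an amide-type nitrogen. Among the measured compounds shown here, with no matched pair to lean on, the step from compound 1 to compound 4 is expected to be modest, toward a somewhat lower number or none beyond the scatter, as a 1.3-fold lower number from compound 1 to compound 4 (0.12 log units; within the scatter). On that basis compound 4 is estimated at 1500 nM in this assay, with a range from 500 nM to 4500 nM.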

Compound 4, half-maximal effective concentration: 8 nM
Compound 4: middle estimate off by 190-fold (2.27 log units), on the high side, outside the stated range (below it).
By their numbers in this assay, from the lowest: compound 4; then compound 2; then compound 1; then compound 3.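

Among these compounds, the first step between compounds differing in one place falls on the amide-type nitrogen: in this assay, cyclopropyl in place of sec-butyl gives a 250-fold lower number from compound 1 to compound 4 (2.40 log units; beyond the scatter), so the activity at this position depends strongly on the group it carries, which compound 1, compound 2 and compound 3 could not show. The change is small by count, from 4 heavy atoms to 3 and from an open chain to a three-membered ring, with no hydrogen-bond donor or acceptor entering or leaving. Nothing at hand accounts for the size of this step.

On these data alone, whether the step belongs to cyclopropyl in particular stays open, since only a group such as methyl, isopropyl or cyclobutyl on this nitrogen of the same core would separate the ring from the chain. Also open, as far as these compounds go, is whether cyclopropyl would have a similar effect on the cores of compound 2 and compound 3, which carry ethyl there.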